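Phenyl for methyl on the shared core of compound 1

The source may hold more compounds than are shown below. What is called first, only, known or untested is meant among the compounds shown, and "the series" means these compounds.

Measured compounds:
compound 1 `Cc1ccc(Oc2ccc(/C=N/n3c(C)nc4ccccc4c3=O)cc2)cc1` with 4.32
compound 2 `Cc1nc2ccccc2c(=O)n1/N=C/c1ccc(Oc2ccc(Br)cc2)cc1` with 4.64
compound 3 `CCCc1nc2ccccc2c(=O)n1/N=C1/C(=O)Nc2ccccc21` with 3.23

In a physicochemical assay for lipophilicity, in phosphate buffer, measured as octanol-water partition (on this read-out lower numbers stand for lower lipophilicity and higher numbers for higher lipophilicity), compound 1 gives 4.32, the second highest of the three numbers. Its nearest neighbour is compound 2, which reaches 4.64, and the step of a number 0.32 log units higher from compound 1 to compound 2 (beyond the scatter) is beyond the scatter. Furthest away is compound 3, which gives 3.23.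

The unmeasured compound 4 `Cc1ccc(Oc2ccc(/C=N/n3c(-c4ccccc4)nc4ccccc4c3=O)cc2)cc1` differs from compound 1 in one place: phenyl in place of methyl on an aromatic carbon. Among the measured compounds shown here, no measured step pairs methyl against phenyl, so the only guide to size is indirect. For the measured compounds named here, the single measured step, a number 0.32 log units higher from compound 1 to compound 2 (beyond the scatter), shows that swapping the methyl of compound 1 for bromo already moves the read-out upward by a modest amount, and the group entering here is considerably larger, with six carbon atoms in an aromatic ring. A rise clearly beyond the scatter is therefore expected, with the step of a number 1.48 log units higher from compound 1 to compound 4 (beyond the scatter) estimated as large. For compound 4 the expected value is 5.8, with a range from 5.2 to 6.4.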

Compound 4, partition coefficient: 6.29
For compound 4 the middle estimate is 0.49 log units below the measured one; the measured number falls inside the stated range.
By their numbers in this assay, from the lowest: compound 3; then compound 1; then compound 2; then compound 4.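

In this assay, the step of a number 1.97 log units higher from compound 1 to compound 4 (beyond the scatter) shows that the read-out responds strongly to a change at the aromatic carbon between two ring nitrogen atoms on the shared core. Among the compounds shown here, the earlier step of a number 0.32 log units higher from compound 1 to compound 2 (beyond the scatter), made at a different methyl of compound 1, was modest, so this is the first large movement seen among compounds differing in one place. The entering phenyl brings one six-membered aromatic ring of carbon only and no hydrogen-bond donors or acceptors. Nothing available explains the size of this step.

The compounds shown leave open how cyclohexyl, a saturated ring of carbon, or an amine would compare with phenyl at this same carbon. They also leave open whether the step would be the same size with bromo in place of the other methyl.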